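Dropping one methoxy group from compound 2

This account rests on a few compounds, and the source may have more. Where it says the series, first, only, none or still open, it means among the compounds named here.

In a functional assay on MDA-MB-231 cells (Homo sapiens) for inhibition, read by MTT assay, with a stated time of 48 h (a lower number here means a stronger inhibitor, a higher number a weaker inhibitor), compound 1 `COc1ccc(-c2nc3cc(/C=C4\SC(=O)NC4=O)ccc3[nH]2)cc1OC` gives 13600 nM. Compound 2 `COc1cc(-c2nc3cc(/C=C4\SC(=O)N(CC(=O)N5CCOCC5)C4=O)ccc3[nH]2)cc(OC)c1OC` gives 14900 nM in this assay; this is the higher of the two numbers, but the gap to compound 1 lies within the scatter. Compound 3 `COc1ccc(-c2nc3cc(/C=C4\SC(=O)N(CC(=O)N5CCOCC5)C4=O)ccc3[nH]2)cc1OC` differs from compound 2 by hydrogen in place of methoxy on an aromatic carbon. Among the measured compounds shown here, no measured pair shows this change on its own. Because compound 1, which carries the same 3,4-dimethoxyphenyl, gives 13600 nM, the step of a 1.1-fold lower number from compound 2 to compound 3 (0.03 log units; within the scatter) is expected to stay within the scatter. Compound 3 is expected to give 14000 nM in this assay, with a range from 6000 nM to 35000 nM.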

Compound 3, half-maximal inhibitory concentration: > 50000 nM
Compound 3: no number, only a limit; the forecaster's own chance of this, stated with the estimate: 5%; at least 3.5-fold (0.55 log units) between middle value and limit.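

In this assay, compound 3 gives a limit and not a number: the limit of > 50000 nM in this assay, at which 1 of the 3 values shown sits. With the ((morpholin-4-yl)carbonyl)methyl group on the ring nitrogen, the methoxy position matters, as 3,4,5-trimethoxyphenyl to 3,4-dimethoxyphenyl gives an at least 3.3-fold higher number from compound 2 to compound 3 (0.52 log units; beyond the scatter). With 3,4-dimethoxyphenyl kept, the same nitrogen group gives an at least 3.6-fold higher number from compound 1 to compound 3 (0.56 log units; beyond the scatter), so the effect of each change depends on the other, which compounds 1 and 2 alone could not show.

The limit leaves the true size of both steps open. Also open, as far as these compounds go, is whether a hydroxy group at the methoxy position, or a carboxylic acid on the nitrogen chain, would behave differently.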